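Swapping Bromo for Methoxy: What the Numbers Suggest

This account rests on a few compounds, and the source may have more. Where it says the series, first, only, none or still open, it means among the compounds named here.

Of the compounds shown here, three sharing one core have been tested in an assay on isolated protein for inhibition of Dopamine beta-hydroxylase (Rattus norvegicus); on this read-out higher numbers stand for weaker inhibition and lower numbers for stronger inhibition. Compound 1 `S=c1[nH]ccn1Cc1ccccc1Cl` gives 355000 nM, compound 2 `S=c1[nH]ccn1Cc1ccc(Br)cc1` gives 115000 nM, and compound 3 `Oc1c(F)cc(Cn2cc[nH]c2=S)cc1F` gives 74.1 nM. Compound 2 therefore holds the second highest number of the three: compound 1 sits higher and compound 3 sits far lower, both gaps lying beyond the scatter. Compound 4 `COc1ccc(Cn2cc[nH]c2=S)cc1` has not yet been measured in this assay. It differs from compound 2 in one place: methoxy in place of bromo on an aromatic carbon. Among the compounds with values here, no measured pair shows this exchange, so nothing points to a shift beyond the scatter. The step from compound 2 to compound 4 is expected to be a 1.3-fold higher number from compound 2 to compound 4 (0.12 log units; within the scatter), meaning little change. Compound 4 is estimated at 150000 nM, with a likely range from 40000 nM to 500000 nM.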

Compound 4, half-maximal inhibitory concentration: 204000 nM
The estimate for compound 4 lay 1.4-fold (0.13 log units) below the measured number; measured number inside the range.
By their numbers in this assay, from the lowest: compound 3; then compounds 2, 4 and 1 (each within the scatter of the next, the first and the last beyond it).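

In this assay, within the data shown here, the first one-place exchange at this position gives a 1.8-fold higher number from compound 2 to compound 4 (0.25 log units; within the scatter) with methoxy in place of bromo on an aromatic carbon. Compounds 2 and 4 therefore cannot be told apart, even though methoxy brings one more heavy atom and a hydrogen-bond acceptor. No measurement shown here explains why the two groups read alike. On these data alone, whether an amine or a carboxylic acid at this place would also leave the number within the scatter stays open. Compound 3 differs from compound 2 in more than one place, so its value cannot be tied to any single group.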